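Arylsulfonamide benzoxazinones: a fluorophenyl for methoxyphenyl swap

A few compounds are considered here, and "the series" means these few. Any claim that something is new, unique, unknown or untested is made for them only; others in the source may bear on it.

Compound 1 `O=C1COc2ccc(-c3cccc(NS(=O)(=O)c4ccc(F)cc4)c3)cc2N1C1CC1`. In a functional assay on HCT-116 cells (Homo sapiens) for antiproliferative activity, read by MTT assay, with a stated time of 72 h (on this read-out higher numbers stand for weaker inhibition and lower numbers for stronger inhibition), compound 1 gives > 40000 nM, a limit of the assay rather than a number.
Compound 2 `O=C1COc2ccc(-c3cccc(NS(=O)(=O)c4ccc(F)cc4)c3)cc2N1c1ccccc1`. In this assay compound 2 gives > 40000 nM, again a limit.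
Compound 3 `COc1cccc(N2C(=O)COc3ccc(-c4cnc(Cl)c(NS(=O)(=O)c5ccc(F)cc5)c4)cc32)c1`. In this assay compound 3 gives > 40000 nM, also a limit.

Compound 3 therefore stands at the same limit as the other two; the step that the two limits leave unreadable from compound 1 to compound 2 is unreadable for the same reason. Compound 4 `O=C1COc2ccc(-c3cnc(Cl)c(NS(=O)(=O)c4ccc(F)cc4)c3)cc2N1c1ccc(F)cc1` differs from compound 3 by 4-fluorophenyl in place of 3-methoxyphenyl on an amide-type nitrogen in a ring. Among the compounds with values here, no measured step bears directly on this change, and the limit of > 40000 nM in this assay, at which 3 of the 3 values shown sit, shows every value shown at the limit, so no shift beyond the scatter can be read in either direction. Compound 4 is expected to give 60000 nM in this assay, within 15000 nM to 200000 nM, which is expected to mean a step that the limit leaves unreadable from compound 3 to compound 4.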

Compound 4, half-maximal inhibitory concentration: 34200 nM
Beside the measured number, compound 4's estimate is 1.8-fold (0.24 log units) above it; low and high end bracket the measured number.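

In this assay compound 4 gives 34200 nM as a number and not a limit, the first readable value among the compounds shown. The change to 4-fluorophenyl in place of 3-methoxyphenyl on this amide-type nitrogen is read as an at least 1.1-fold lower number from compound 3 to compound 4 (0.06 log units; that floor lies within the scatter) and so establishes no shift beyond the scatter. Its true size and the step between the other compounds cannot be read, because most values sit at a limit: the limit of > 40000 nM in this assay, at which 3 of the 4 values shown sit.

Going by these compounds, whether a fluorine on the phenyl ring matters at all stays open. So does whether an amine or a carboxylic acid on that ring would give a step beyond the scatter.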